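Trifluoromethoxy in Place of Iodo: Expected Maximal Response

The compounds below may be only part of what the source reports. "The series", "measured", "known", "first", "only" and "open" are said of these compounds alone.

Within the data shown here, in a functional assay on the whole organism (aorta) with Rattus norvegicus as the target (a higher number here means a larger maximal response, a lower number a smaller maximal response), compound 2 `O=C1C(Nc2ccc(I)cc2)=CC(=O)c2ncccc21` gives 89%, the highest of the two numbers measured so far, while compound 1 `O=C1C(Nc2ccc(Cl)cc2)=CC(=O)c2ncccc21` gives 86%. Among the measured compounds shown here, the only measured step, a number 3 percentage points higher from compound 1 to compound 2 (within the scatter), exchanged one group for another at the same aromatic carbon and stayed within the scatter. Compound 3 `O=C1C(Nc2ccc(OC(F)(F)F)cc2)=CC(=O)c2ncccc21` differs from compound 2 by trifluoromethoxy in place of iodo on an aromatic carbon. Because a number 3 percentage points higher from compound 1 to compound 2 (within the scatter) stayed within the scatter, compound 3 is expected to show a number 4 percentage points lower from compound 2 to compound 3 (within the scatter), again within the scatter. Compound 3 is therefore estimated at 85%, with a range from 74% to 96%.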

Compound 3, largest response reached (Emax), in percent of the reference or control that the assay uses: 88%
Beside the measured number, compound 3's estimate is 3 percentage points below it, within the range that was stated.
By their numbers in this assay, from the lowest: compounds 1, 3 and 2 (each within the scatter of the next).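

At this aromatic carbon, trifluoromethoxy, with its 5 heavy atoms and 1 hydrogen-bond acceptor, stands in place of iodo with a number 1 percentage points lower from compound 2 to compound 3 (within the scatter) and in place of chloro with a number 2 percentage points higher from compound 1 to compound 3 (within the scatter). The earlier pair compared only two halogens, whereas this result extends the same narrow band in this assay to a non-halogen group containing oxygen and fluorine. Nothing available explains this outcome. The compounds shown leave open whether an amine, a carboxylic acid or a longer alkyl chain at this carbon would stay within the scatter of these three. They also leave open how far the maximal response depends on this position at all.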